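Benzyl variation on the bis(trifluoromethyl)sulfonamide series

The source may hold more compounds than are shown below. What is called first, only, known or untested is meant among the compounds shown, and "the series" means these compounds.

Compounds measured in a functional assay on HT-29 cells (Homo sapiens) for inhibition, read by MTT assay, with a stated time of 72 h; on this read-out higher numbers stand for weaker inhibition of growth and lower numbers for stronger inhibition of growth:
compound 1, `CN(CCCNS(=O)(=O)c1cc(C(F)(F)F)cc(C(F)(F)F)c1)Cc1ccccc1`: > 50000 nM, which is a limit of the assay rather than a number, (the limit of > 50000 nM in this assay, at which 1 of the 3 values shown sits).
compound 2, `O=S(=O)(NCCCNCc1ccc(Br)cc1)c1cc(C(F)(F)F)cc(C(F)(F)F)c1`: 2200 nM.
compound 3, `O=S(=O)(NCCCNCc1cccc2ccccc12)c1cc(C(F)(F)F)cc(C(F)(F)F)c1`: 2600 nM.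

Compound 3 carries the highest of the two numbers that are numbers at all, and its nearest neighbour is compound 2; the two sit within the scatter of each other, so no order between them can be read. The step of a 1.2-fold higher number from compound 2 to compound 3 (0.07 log units; within the scatter) shows that exchanging one aryl group for another on the saturated chain carbon bound to the amine nitrogen left the read-out essentially unchanged. The large step of an at least 22-fold lower number from compound 1 to compound 2 (1.35 log units; beyond the scatter) concerns the amine substitution itself and does not bear on an aryl exchange.

Compound 4, `O=S(=O)(NCCCNCc1cccc(Cl)c1)c1cc(C(F)(F)F)cc(C(F)(F)F)c1`, is the next member: 3-chlorophenyl in place of naphthalen-1-yl on a saturated chain carbon bound to an amine nitrogen. For the measured compounds named here, the only measured step that matches this kind of change, from compound 2 to compound 3, was within the scatter, so the step of a 1.0-fold lower number from compound 3 to compound 4 (0.02 log units; within the scatter) is expected to be small, with no direction that can be claimed. Compound 4 is therefore estimated at 2500 nM in this assay, with a range from 900 nM to 7000 nM.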

Compound 4, concentration for 50% growth inhibition: 14000 nM
Compound 4: middle estimate off by 5.6-fold (0.75 log units), on the low side; measured number above the stated range.
By their numbers in this assay, from the lowest: compounds 2 and 3 (each within the scatter of the next); then compound 4. At a limit, above all of these: compound 1.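

In this assay, the aryl group on the saturated chain carbon bound to an amine nitrogen is not freely exchangeable: the step of a 5.4-fold higher number from compound 3 to compound 4 (0.73 log units; beyond the scatter) and the step of a 6.4-fold higher number from compound 2 to compound 4 (0.80 log units; beyond the scatter) both lie beyond the scatter, whereas 4-bromophenyl and naphthalen-1-yl gave values within the scatter of each other. That earlier pair therefore does not show tolerance for any aryl group at this place, since 3-chlorophenyl stands apart from both. The step of an at least 3.5-fold lower number from compound 1 to compound 4 (0.55 log units; beyond the scatter) shows that compound 4, though it carries the highest of the three true numbers, still lies clear of compound 1, whose value is a limit of the assay and can only give a bound on this step: the limit of > 50000 nM in this assay, at which 1 of the 4 values shown sits.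

On these data alone, whether the gap between 3-chlorophenyl and 4-bromophenyl follows the halogen or where it sits on the ring stays open, and a 4-chlorophenyl or 3-bromophenyl group would separate the two. Also open, as far as these compounds go, is how a plain benzyl group on the same amine nitrogen would read, which would separate the effect of the methyl group in compound 1 from that of the aryl substituents.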